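Replacing (2-aminoethyl)amino in compound 3

A few compounds are considered here, and "the series" means these few. Any claim that something is new, unique, unknown or untested is made for them only; others in the source may bear on it.

Of the compounds shown here, three on one shared core have been measured in a functional assay on MCF7 cells (Homo sapiens), read by MTT assay, with a stated time of 48 h; a lower number here means a stronger inhibitor, a higher number a weaker inhibitor. Compound 1 `CCOC(=O)CN(C)C(=O)c1ccc(C(CC)(CC)c2ccc(OCC(O)C(C)(C)C)c(C)c2)n1CC` gives 9200 nM. For compound 2 `CCn1c(C(=O)NCC(OC)OC)ccc1C(CC)(CC)c1ccc(OCC(O)C(C)(C)C)c(C)c1` the assay reports only a limit, > 50000 nM. Compound 3 `CCn1c(C(=O)NCCN)ccc1C(CC)(CC)c1ccc(OCC(O)C(C)(C)C)c(C)c1` gives 5.9 nM, the lowest number of the three, and the measured steps to it are large: a 1600-fold lower number from compound 1 to compound 3 (3.19 log units; beyond the scatter) and an at least 8400-fold lower number from compound 2 to compound 3 (3.92 log units; beyond the scatter).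

Compound 4 `C#CC(C)OC(=O)c1ccc(C(CC)(CC)c2ccc(OCC(O)C(C)(C)C)c(C)c2)n1CC` carries one change from compound 3, ((1-methylprop-2-yn-1-yl)oxy in place of (2-aminoethyl)amino on a carbonyl carbon), on a carbonyl carbon. Within the data shown here, no measured step makes this exact replacement. However, compound 4 gives up the (2-aminoethyl)amino that only compound 3 carries, so the two large steps above bear on it in reverse. Those steps point to a large rise in this assay. The groups that replace (2-aminoethyl)amino also matter, as an at least 5.4-fold higher number from compound 1 to compound 2 (0.73 log units; beyond the scatter) shows, so the size of the rise remains uncertain. The expected change is a 2000-fold higher number from compound 3 to compound 4 (3.31 log units; beyond the scatter). For compound 4 the estimated value is 12000 nM, with an expected range from 2500 nM to 50000 nM.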

Compound 4, half-maximal inhibitory concentration: > 50000 nM
Compound 4 ended at the assay's limit; the forecaster's own chance of this, stated with the estimate: 30%; at least 4.1-fold (0.61 log units) between middle value and limit.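

In this assay compound 4 gives > 50000 nM, which is a limit of the assay and not a number. Until now only amino groups had stood on this carbonyl carbon, and (1-methylprop-2-yn-1-yl)oxy in that place gives an at least 8400-fold higher number from compound 3 to compound 4 (3.92 log units; beyond the scatter) and also an at least 5.4-fold higher number from compound 1 to compound 4 (0.73 log units; beyond the scatter), so this oxy group, like the amino groups of compound 1 and compound 2, stays far from the low number of compound 3. The step between compound 2 and compound 4 cannot be read, since both values stand at the same limit: the limit of > 50000 nM in this assay, at which 2 of the 4 values shown sit.

As far as these compounds go, how far compound 4 lies beyond its limit remains unknown. From the compounds shown here alone, it also remains open whether a longer chain such as (3-aminopropyl)amino, or a (2-(dimethylamino)ethyl)amino group, on this carbonyl carbon would keep the low number of compound 3.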